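The compounds below may be only part of what the source reports. "The series", "measured", "known", "first", "only" and "open" are said of these compounds alone.

Measured compounds in a toxicity assay on GES1 cells (Homo sapiens) for inhibition, read by MTT assay, with a stated time of 72 h; on this read-out higher numbers stand for weaker inhibition and lower numbers for stronger inhibition:
- compound 1 `Cc1cc(N2CC[C@@H](C)[C@@H](N(C)c3ncnc4[nH]ccc34)C2)n2nc(SCC3CC3)nc2n1`: 27900 nM
- compound 2 `Cc1nc2nc(SCc3ccc(Cl)cc3)nn2c(N2CC[C@@H](C)[C@@H](N(C)c3ncnc4[nH]ccc34)C2)c1C`: 99200 nM
- compound 3 `C=CCSc1nc2nc(C)cc(N3CC[C@@H](C)[C@@H](N(C)c4ncnc5[nH]ccc45)C3)n2n1`: in this assay compound 3 reaches only the limit > 100000 nM, a limit rather than a number.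

Among the two plain numbers compound 1 stands lowest; compound 2 sits higher by a gap beyond the scatter. Compound 4 `Cc1ccc(CSc2nc3nc(C)cc(N4CC[C@@H](C)[C@@H](N(C)c5ncnc6[nH]ccc56)C4)n3n2)cc1` has not been measured. It differs from compound 1 by 4-methylphenyl in place of cyclopropyl on a saturated chain carbon bound to a sulfur. Going by the values given here, the one step measured at that place, an at least 3.5-fold higher number from compound 1 to compound 3 (0.55 log units; beyond the scatter), reaches only (the limit of > 100000 nM in this assay, at which 1 of the 3 values shown sits). Both compound 2 and compound 3 thus sit well above compound 1, so a step upward to weaker inhibition is expected in this assay, a 2.9-fold higher number from compound 1 to compound 4 (0.46 log units; beyond the scatter). Compound 4 is estimated at 80000 nM, between 30000 nM and 200000 nM, with a fair chance that only a limit is reported.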

Compound 4, half-maximal inhibitory concentration: 82500 nM
Beside the measured number, compound 4's estimate is 1.0-fold (0.01 log units) below it, and the stated range covers the measured number.
By their numbers in this assay, from the lowest: compound 1; then compounds 4 and 2 (each within the scatter of the next). At a limit, above all of these: compound 3.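

At the saturated chain carbon bound to a sulfur, 4-methylphenyl in place of cyclopropyl gives a fully measured step in this assay: a 3.0-fold higher number from compound 1 to compound 4 (0.47 log units; beyond the scatter). Going by these compounds alone, the earlier step at this place ended at a limit, so this is the first full size for a change there, and it shows the upward direction also with an aromatic ring. The other step, an at least 1.2-fold lower number from compound 3 to compound 4 (0.08 log units; that floor lies within the scatter), rests on a limit and sets no order.

From the compounds shown here alone, whether an amine, a carboxylic acid or a longer chain at this place would give a similar number remains open.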